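Methyl in place of chloro on the core of compound 2

A few compounds are considered here, and "the series" means these few. Any claim that something is new, unique, unknown or untested is made for them only; others in the source may bear on it.

Working notes on three measured compounds and one unmeasured. All values come from an assay on isolated protein for inhibition of complement C1r subcomponent (Homo sapiens); on this read-out higher numbers stand for weaker inhibition and lower numbers for stronger inhibition. Compound 1 `O=c1oc(Nc2ccccc2I)nc2ccccc12` gives 3500 nM in this assay. Compound 2 `O=c1oc(Nc2ccccc2I)nc2cccc(Cl)c12` gives 14500 nM in this assay, the highest of the two numbers shown, and the step of a 4.1-fold higher number from compound 1 to compound 2 (0.62 log units; beyond the scatter) is chloro in place of hydrogen on an aromatic carbon of the shared core. Compound 3 `O=c1oc(Nc2ccccc2I)nc2cc(Cl)cc(Cl)c12` sits at > 62500 nM in this assay, which is a limit of the assay and not a number (the limit of > 62500 nM in this assay, at which 1 of the 3 values shown sits). The second chloro step, an at least 4.3-fold higher number from compound 2 to compound 3 (0.63 log units; beyond the scatter), is therefore known only as a floor.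

Compound 4 `Cc1cccc2nc(Nc3ccccc3I)oc(=O)c12` differs from compound 2 by methyl in place of chloro on an aromatic carbon. Within the data shown here, both measured steps add a chloro to the shared core and both raise the number; neither step covers a methyl, and no measured pair exchanges one small substituent for another at this carbon. The change keeps one heavy atom at the same place, so in this assay the expectation for compound 4 is a number close to that of compound 2, not beyond the scatter, leaning toward compound 1. The estimated step is a 1.5-fold lower number from compound 2 to compound 4 (0.16 log units; within the scatter). The estimate for compound 4 is 10000 nM, between 3500 nM and 30000 nM.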

Compound 4, half-maximal inhibitory concentration: > 62500 nM
Compound 4: a limit, no number (the forecaster's own chance of this, stated with the estimate: 5%); middle value at least 6.2-fold (0.79 log units) from the limit.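

In this assay compound 4 reads > 62500 nM, which is a limit of the assay and not a number. Methyl does not stand in for chloro on this aromatic carbon: the exchange gives an at least 4.3-fold higher number from compound 2 to compound 4 (0.63 log units; beyond the scatter), and against the hydrogen of the shared core the change gives an at least 17-fold higher number from compound 1 to compound 4 (1.25 log units; beyond the scatter), so chloro is no longer the only group shown to raise the number at this place. Both steps are floors, so the full size of the methyl step cannot be read, and the series has no upper end for it: the limit of > 62500 nM in this assay, at which 2 of the 4 values shown sit.

Going by these compounds, whether any group on this aromatic carbon would lower the number, or keep it near that of compound 1, at 3500 nM, stays open, for example an amine, a hydroxyl or a carboxylic acid, and fluoro as a smaller halogen. Also open, on these data alone, is how methyl would read on the other core carbon that carries chloro in compound 3, in a compound with no substituent on the carbon studied here.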